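This account rests on a few compounds, and the source may have more. Where it says the series, first, only, none or still open, it means among the compounds named here.

Three ureas that share one core have been tested in a functional assay on HepG2 cells (Homo sapiens) for inhibition, read by MTT assay, with a stated time of 72 h; a lower number here means a stronger inhibitor, a higher number a weaker inhibitor. Compound 1 `O=C(Nc1cccc(OCc2cn(-c3ccccc3)nn2)c1)Nc1ccc(Cl)c(C(F)(F)F)c1` carries a plain phenyl on the five-membered ring and gives 1780 nM. Compound 2 `COc1ccc(-n2cc(COc3cccc(NC(=O)Nc4ccc(Cl)c(C(F)(F)F)c4)c3)nn2)cc1` carries a 4-methoxyphenyl there instead and gives 4680 nM, the second highest of the three numbers; compound 3 `Cc1cccc(-n2cc(COc3cccc(NC(=O)Nc4ccc(Cl)c(C(F)(F)F)c4)c3)nn2)c1` carries a 3-methylphenyl and gives 7270 nM. The steps show a 2.6-fold higher number from compound 1 to compound 2 (0.42 log units; beyond the scatter) and a 4.1-fold higher number from compound 1 to compound 3 (0.61 log units; beyond the scatter), while a 1.6-fold higher number from compound 2 to compound 3 (0.19 log units; within the scatter), so compound 2 and compound 3 cannot be told apart, and both sit clearly higher than compound 1.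

Compound 4 `O=C(Nc1cccc(OCc2cn(-c3cccc(F)c3)nn2)c1)Nc1ccc(Cl)c(C(F)(F)F)c1` is the next member. 3-fluorophenyl in place of 4-methoxyphenyl on an aromatic nitrogen

For the measured compounds named here, the step that bears most directly on this change is the one from compound 2 to compound 3, which swapped one substituted phenyl for another and stayed within the scatter. The other two steps suggest that any substituent on that phenyl pushes the number upward from the plain phenyl of compound 1. A fluorine is a smaller group than the methoxy it replaces, so the expected result for compound 4 lies between the numbers of compound 1 and compound 2, meaning a 1.6-fold lower number from compound 2 to compound 4 (0.19 log units; within the scatter). Compound 4 is therefore estimated at 3000 nM, with a range from 1200 nM to 7500 nM.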

Compound 4, half-maximal inhibitory concentration: 2120 nM
For compound 4 the middle estimate is 1.4-fold (0.15 log units) above the measured one, and the stated range covers the measured number.
By their numbers in this assay, from the lowest: compounds 1 and 4 (each within the scatter of the next); then compounds 2 and 3 (each within the scatter of the next).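

Until now, each group added to the phenyl on the aromatic nitrogen had come with a number clearly higher than that of the plain phenyl, but compound 4 goes against this in this assay and cannot be told apart from compound 1 (a 1.2-fold higher number from compound 1 to compound 4 (0.08 log units; within the scatter)). So a substituent on this phenyl does not by itself separate a compound from the plain phenyl; what matters is which group it is, as the change from methyl to fluoro at the same ring carbon shows (a 3.4-fold lower number from compound 3 to compound 4 (0.54 log units; beyond the scatter)), and compound 4 also stands apart from the 4-methoxyphenyl compound (a 2.2-fold lower number from compound 2 to compound 4 (0.34 log units; beyond the scatter)), though that change alters both the group and where it sits on the ring. Nothing measured here explains why these groups differ.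

The compounds shown leave open whether the low number belongs to fluoro as such or to fluoro at this ring carbon, a question that a 4-fluorophenyl would address. They also leave open how a chloro, an amine or a carboxylic acid on this phenyl would compare with the plain phenyl of compound 1.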